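Imidazolyl to Thiazolyl on the Shared Core: an Expected Binding Value

This account rests on a few compounds, and the source may have more. Where it says the series, first, only, none or still open, it means among the compounds named here.

Compound 1 `Cc1ccncc1-c1cc(F)cc(-n2nnc(-c3ncc[nH]3)n2)c1`: 3.5 nM
Compound 2 `N#Cc1cccc(-n2nnc(-c3ncc[nH]3)n2)c1`: 34 nM

Of the compounds shown here, two have been measured in an assay for binding affinity to metabotropic glutamate receptor 5 (Rattus norvegicus); on this read-out higher numbers stand for weaker inhibition and lower numbers for stronger inhibition. Compound 1 gives 3.5 nM in this assay, and compound 2 gives 34 nM in this assay. Compound 2 therefore carries the higher of the two numbers, which means the weaker binding, and its gap to compound 1 lies beyond the scatter. Since compound 1 and compound 2 differ in more than one place, this gap cannot be tied to any single change.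

Compound 3 `N#Cc1cccc(-n2nnc(-c3nccs3)n2)c1` has not yet been measured. It differs from compound 2 in one place only: 1,3-thiazol-2-yl in place of 1H-imidazol-2-yl on an aromatic carbon. Among the compounds with values here, no pair of measured compounds shows this exchange, so there is no measured step to lean on, and the expectation rests on compound 2 alone. Compound 3 is expected to bind somewhat less strongly than compound 2, with a step that may still fall within the scatter; the expected step is a 1.6-fold higher number from compound 2 to compound 3 (0.21 log units; within the scatter) in this assay. For compound 3, an inhibition constant of about 55 nM is estimated, within a range from 14 nM to 220 nM.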

Compound 3, inhibition constant: 183 nM
Compound 3: the middle estimate sits 3.3-fold (0.52 log units) below what was measured, within the range that was stated.
By their numbers in this assay, from the lowest: compound 1; then compound 2; then compound 3.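

In this assay, within the data shown here, putting 1,3-thiazol-2-yl in place of 1H-imidazol-2-yl gives a 5.4-fold higher number from compound 2 to compound 3 (0.73 log units; beyond the scatter), which is the first change in this set that can be read in one place alone. It shows that this aromatic carbon of the five-membered aromatic ring with 4 nitrogen is sensitive to the identity of its group: the two groups are both five-membered aromatic rings with 2 hetero atoms and the same number of heavy atoms, yet binding weakens beyond the scatter. The exchange swaps one ring nitrogen for sulfur and goes from 1 hydrogen-bond donor to 0 hydrogen-bond donors, but nothing available here separates these two differences or explains the step.

The compounds shown leave open which of those differences matters, and a 1-methyl-1H-imidazol-2-yl group, which keeps the ring nitrogen atoms but has a methyl on the ring nitrogen in place of its hydrogen, would be a direct probe of that question. They also leave open whether the same exchange would cost as much on the core of compound 1, with its methylpyridinyl and fluorine-bearing parts.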